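Removing the chloro from the aryl ring of compound 1

The source may hold more compounds than are shown below. What is called first, only, known or untested is meant among the compounds shown, and "the series" means these compounds.

Working notes on a small set built on one shared core. In a functional assay on CHO cells for agonist activity at metabotropic glutamate receptor 2 (Homo sapiens), read by FLIPR (a lower number here means that less compound is needed, a higher number that more compound is needed for the effect), compound 1 `Cn1c(CN2CCN(c3ccc(Cl)cc3F)CC2)nc2ccccc21` gives 2510 nM, the lowest of the two numbers in hand. Compound 2 `Cn1c(CN2CCN(c3ccc(C(F)(F)F)cn3)CC2)nc2ccccc21` gives 6310 nM in this assay, a higher number than compound 1. Compound 3 `Cn1c(CN2CCC(c3ccccn3)CC2)nc2ccccc21` reaches only a limit of this assay, > 15800 nM; that is the limit of > 15800 nM in this assay, at which 1 of the 3 values shown sits. Compound 4 `Cn1c(CN2CCN(c3ccccc3F)CC2)nc2ccccc21` is not yet measured; it differs from compound 1 by hydrogen in place of chloro on an aromatic carbon. Loss of the chloro is expected to cost some potency, so the step of a 2.5-fold higher number from compound 1 to compound 4 (0.40 log units; beyond the scatter) is estimated to raise the number beyond the scatter. Compound 4 is thus expected at about 6300 nM, within 2000 nM to 20000 nM.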

Compound 4, half-maximal effective concentration: 6310 nM
Compound 4: the middle estimate sits 1.0-fold (0.00 log units) below what was measured; the range from low to high includes it.
By their numbers in this assay, from the lowest: compound 1; then compounds 2 and 4 (each within the scatter of the next). At a limit, above all of these: compound 3.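

In this assay, among the compounds shown here, the step of a 2.5-fold higher number from compound 1 to compound 4 (0.40 log units; beyond the scatter) is the first one that can be read at a single position, and it lies beyond the scatter. For the compounds shown here, with the fluoro group and the shared core unchanged, the chloro on this aromatic carbon carries a modest part of the activity, which the earlier compounds, differing in more than one place, could not show. Nothing in hand gives a cause for this step. Still open, on these data alone, is whether bromo, methyl, methoxy or nitrile at this position would match chloro.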